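Flipping one ring stereocentre on a kinase inhibitor fragment

A few compounds are considered here, and "the series" means these few. Any claim that something is new, unique, unknown or untested is made for them only; others in the source may bear on it.

Compound 3 `C[C@H]1CCCN1c1c(C#N)c2c(N)ncnc2n1C` is the weakest binder among the three compounds measured in an assay on isolated protein for binding affinity to Leucine-rich repeat serine/threonine-protein kinase 2 variant G2019S (Homo sapiens), read by TR-FRET and LanthaScreen, with a stated time of 2 h (a lower number here means a stronger inhibitor, a higher number a weaker inhibitor), where compound 3 gives 212 nM. Compound 1 `Cc1nn(C)cc1Nc1nc(N)c2c(C#N)c(N3CCC[C@H]3C)n(C)c2n1` gives 2 nM, and compound 2 `C[C@@H]1CCCN1c1c(C#N)c2c(N)nc(Nc3cn[nH]c3)nc2n1C` gives 0.4 nM; the change from compound 1 to compound 2, a 1H-pyrazol-4-yl in place of 1,3-dimethyl-1H-pyrazol-4-yl on a nitrogen on an aromatic ring, gave a 5.0-fold lower number from compound 1 to compound 2 (0.70 log units; beyond the scatter).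

Compound 4 `C[C@@H]1CCCN1c1c(C#N)c2c(N)ncnc2n1C` has not yet been measured. Its relation to compound 3 is the two compounds have the same atoms and bonds and differ only in configuration as drawn: 1 of 1 stereo elements differ; a stereocentre at a saturated ring carbon is drawn S in compound 3 and R in compound 4. For the measured compounds named here, no measured step in this set changes configuration alone; the only measured step swaps a substituent, so it does not bear directly on this change. A change of configuration at a saturated ring carbon can leave the number nearly unchanged or shift it strongly in either direction, and nothing here fixes which. For compound 4 the expected value in this assay is 100 nM, within a range of 25 nM to 400 nM, which means an estimated step of a 2.1-fold lower number from compound 3 to compound 4 (0.33 log units; beyond the scatter).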

Compound 4, inhibition constant: 0.7 nM
Estimate against measurement, compound 4: 140-fold (2.15 log units) above; measured number outside the range, below it.
By their numbers in this assay, from the lowest: compounds 2 and 4 (each within the scatter of the next); then compound 1; then compound 3.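

Configuration at this saturated ring carbon turns out to be decisive in this assay, where the change gives a 300-fold lower number from compound 3 to compound 4 (2.48 log units; beyond the scatter) as its step, and this large gap belongs to the stereocentre alone because nothing else separates the two compounds (in short: the fact that compounds 3 and 4 differ only in the configuration as drawn). For the compounds shown here, the earlier compounds could not show this, since their only measured step swaps a substituent. The (1H-pyrazol-4-yl)amino group also proves unnecessary for strong binding here: hydrogen in its place gives a 1.8-fold higher number from compound 2 to compound 4 (0.24 log units; within the scatter) as its step, while hydrogen in place of (1,3-dimethyl-1H-pyrazol-4-yl)amino gives a 2.9-fold lower number from compound 1 to compound 4 (0.46 log units; beyond the scatter) as its step.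

Still open, going by these compounds, is whether either of these amino groups would change the gap between the two configurations. Also open, on these data alone, is how an ethyl group or a carboxylic acid at that stereocentre would fare.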